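Swapping the fluorophenyl for a spiro-fused saturated ring

The source may hold more compounds than are shown below. What is called first, only, known or untested is meant among the compounds shown, and "the series" means these compounds.

Measured in an assay on HEK293 cells for negative allosteric modulation of metabotropic glutamate receptor 5 (Homo sapiens), read by FLIPR; a higher number here means a weaker inhibitor, a lower number a stronger inhibitor:
compound 1 `CC1CCCC(C(=O)N2CC(c3nc(-c4cccc(Cl)c4)no3)C2)C1` gives > 10000 nM, which is a limit of the assay and not a number.
compound 2 `O=C(c1cccc(F)c1)N1CC(c2nc(-c3cccc(Cl)c3)no2)C1` gives 780 nM.
compound 3 `O=C(c1ccccc1F)N1CC(c2nc(-c3cccc(Cl)c3)no2)C1` gives 670 nM.

Compound 3 holds the lowest of the two numbers shown, with compound 2 close by, a 1.2-fold lower number from compound 2 to compound 3 (0.07 log units; within the scatter). Compound 4 `O=C(C1CCC2(CCC2)CC1)N1CC(c2nc(-c3cccc(Cl)c3)no2)C1` differs from compound 3 in one place: a group of 9 heavy atoms (9 carbon; one four-membered non-aromatic ring of carbon only, one six-membered non-aromatic ring of carbon only) in place of a group of 7 heavy atoms (6 carbon, 1 fluorine; one six-membered aromatic ring of carbon only), on a carbonyl carbon. Within the data shown here, the steps that bear on this are those in which a saturated ring gave way to an aromatic one, an at least 14-fold lower number from compound 1 to compound 3 (1.17 log units; beyond the scatter) and an at least 12-fold lower number from compound 1 to compound 2 (1.10 log units; beyond the scatter). Compound 4 returns to a saturated ring, so the reverse is expected, a large rise, a 13-fold higher number from compound 3 to compound 4 (1.13 log units; beyond the scatter), quite possibly back to the limit (the limit of > 10000 nM in this assay, at which 1 of the 3 values shown sits). Compound 4 is therefore estimated at 9000 nM, within a range from 2500 nM to 30000 nM.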

Compound 4, half-maximal inhibitory concentration: > 10000 nM
Compound 4 ended at the assay's limit; the forecaster's own chance of this, stated with the estimate: 50%; at least 1.1-fold (0.04 log units) between middle value and limit.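

On this carbonyl carbon, losing the aromatic ring now proves costly with a second saturated group, not only with 3-methylcyclohexyl: the change gives an at least 14-fold higher number from compound 3 to compound 4 (1.17 log units; beyond the scatter) and an at least 12-fold higher number from compound 2 to compound 4 (1.10 log units; beyond the scatter). Compound 4 gives > 10000 nM, which is a limit of the assay and not a number. The step from compound 1 to compound 4 cannot be read, and both saturated groups now sit at the same limit: the limit of > 10000 nM in this assay, at which 2 of the 4 values shown sit.

On these data alone, whether a saturated ring carrying a carboxylic acid or an amine could do better remains open. So does how an unsubstituted phenyl or a pyridine would compare with the fluorophenyl groups.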